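The compounds below may be only part of what the source reports. "The series", "measured", "known", "first", "only" and "open" are said of these compounds alone.

For the measured compounds named here, compound 2 `N=C(NCCCc1c[nH]cn1)NCCC(c1ccccn1)c1cccs1` gives 45.7 nM in a functional assay on ileum for antagonist activity at histamine H1 receptor (Cavia porcellus) (a lower number here means tighter binding, a higher number weaker binding), the higher of the two numbers measured so far. Going by the values given here, compound 1 `N=C(NCCCc1c[nH]cn1)NCCC(c1ccc(F)cc1)c1ccccn1` gives 22.4 nM in this assay, and the one step measured, a 2.0-fold higher number from compound 1 to compound 2 (0.31 log units; beyond the scatter), shows how much a swap of the aromatic group on that chain carbon can move the number. Compound 3 `N=C(NCCCc1c[nH]cn1)NCCC(c1ccccn1)c1ccccn1` differs from compound 2 in the same position: pyridin-2-yl in place of thiophen-2-yl on a saturated chain carbon bound to an aromatic carbon and a saturated chain carbon. Among the compounds with values here, no measured step matches this exact exchange, so the only guide is the modest size of the step from compound 1 to compound 2, which involved a different pair of rings at the same place. On that basis the step from compound 2 to compound 3 is expected to be small, a 1.3-fold higher number from compound 2 to compound 3 (0.12 log units; within the scatter), with no clear direction. Compound 3 is therefore estimated at 60 nM in this assay, within a range from 20 nM to 180 nM.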

Compound 3, dissociation constant: 389 nM
Compound 3: middle estimate off by 6.5-fold (0.81 log units), on the low side, outside the stated range (above it).
By their numbers in this assay, from the lowest: compound 1; then compound 2; then compound 3.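

In this assay, for the compounds shown here, the group on this chain carbon matters far more than the first pair of compounds suggested: pyridin-2-yl in place of thiophen-2-yl gives an 8.5-fold higher number from compound 2 to compound 3 (0.93 log units; beyond the scatter), a much larger move than a 2.0-fold higher number from compound 1 to compound 2 (0.31 log units; beyond the scatter). Pyridin-2-yl in place of 4-fluorophenyl gives a 17-fold higher number from compound 1 to compound 3 (1.24 log units; beyond the scatter), so compound 3 binds most weakly of the three. Thiophen-2-yl and pyridin-2-yl have the same counts of hetero atoms and hydrogen-bond acceptors, so those counts alone do not set the number at this position.

Nothing available here explains why the number rises so sharply with pyridin-2-yl. From the compounds shown here alone, it also remains open how an unsubstituted phenyl ring or a pyridin-3-yl ring on the same carbon would compare with these three groups.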